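Swapping the Aryl Group on a Fused Sulfone Core

A few compounds are considered here, and "the series" means these few. Any claim that something is new, unique, unknown or untested is made for them only; others in the source may bear on it.

Compound 3 `O=S(=O)(c1ccc(F)c(F)c1)c1cnc2c(F)cccc2c1-c1cccc(Cl)c1` gives 1.13 mL/min in an ADME assay on microsomes from liver (Homo sapiens) for metabolic stability, tested at 2.5 uM (a higher number here means faster removal of the compound, a lower number slower removal), the smallest of the three numbers shown; compound 1 `O=S(=O)(c1ccc(F)c(F)c1)c1cnc2c(F)cccc2c1-c1ccccc1F` gives 1.39 mL/min, within the scatter of it, while compound 2 `COc1ccc(-c2c(S(=O)(=O)c3ccc(F)cc3)cnc3c(F)cccc23)cc1` gives 2.41 mL/min, beyond the scatter. Compound 4 `COc1ccc(-c2c(S(=O)(=O)c3ccc(F)c(F)c3)cnc3c(F)cccc23)cc1` differs from compound 3 by 4-methoxyphenyl in place of 3-chlorophenyl on an aromatic carbon. Among the compounds with values here, the only measured step at this position, a 1.2-fold lower number from compound 1 to compound 3 (0.09 log units; within the scatter), lay within the scatter and so gives no direction. Compound 2, which carries the same 4-methoxyphenyl that enters, gives 2.41 mL/min, a higher number than compound 3 shows, so a rise is expected. Compound 4 is therefore estimated at 2 mL/min, with a range from 1.1 mL/min to 3.6 mL/min. The expected step is a 1.8-fold higher number from compound 3 to compound 4 (0.25 log units; within the scatter).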

Compound 4, intrinsic clearance in a liver preparation (reported as CLH), per the amount of preparation that the assay uses: 2.12 mL/min
Estimate against measurement, compound 4: 1.1-fold (0.03 log units) below; the range from low to high includes it.
By their numbers in this assay, from the lowest: compounds 3, 1, 4 and 2 (each within the scatter of the next, the first and the last beyond it).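

In this assay, within the data shown here, 4-methoxyphenyl in place of 3-chlorophenyl gives a 1.9-fold higher number from compound 3 to compound 4 (0.27 log units; within the scatter), and 4-methoxyphenyl in place of 2-fluorophenyl gives a 1.5-fold higher number from compound 1 to compound 4 (0.18 log units; within the scatter), so three aryl groups at this position now stand compared, with no step among them beyond the scatter. Fluoro in place of hydrogen on an aromatic carbon, away from this position, gives a 1.1-fold lower number from compound 2 to compound 4 (0.06 log units; within the scatter), which also stays within the scatter. Nothing measured bears on the reason for these numbers.

The compounds shown leave open whether an amine, a carboxylic acid or a longer chain at this position would give a step beyond the scatter in this assay.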